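Aryl esters of the shared core: nitro for trifluoromethyl

The compounds below may be only part of what the source reports. "The series", "measured", "known", "first", "only" and "open" are said of these compounds alone.

Measured so far in a functional assay on U-251 cells (Homo sapiens) for antiproliferative activity, read by sulforhodamine B assay, with a stated time of 48 h, tested at 50 uM; a lower number here means less inhibition, a higher number more inhibition at the concentration tested (going by the name of the read-out):
compound 1 `COc1cccc(C(=O)Oc2cc3c(cc2C)[C@@H](C(C)C)CC=C3C)c1`: "not active" (no number reported)
compound 2 `CC1=CC[C@H](C(C)C)c2cc(C)c(OC(=O)c3ccc([N+](=O)[O-])cc3)cc21`: 16.8%
compound 3 `CC1=CC[C@H](C(C)C)c2cc(C)c(OC(=O)c3cccc(C(F)(F)F)c3)cc21`: 29.3%

Three esters of the shared core have been run in this assay. Compound 1 returned "not active" (no number reported), so it contributes no number. Among the two numbers, compound 3 stands highest; compound 2 sits below it by a gap beyond the usual scatter, so the order of these two is real.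

Compound 4 `CC1=CC[C@H](C(C)C)c2cc(C)c(OC(=O)c3cccc([N+](=O)[O-])c3)cc21` is not yet measured. It differs from compound 3 in one place: nitro in place of trifluoromethyl on an aromatic carbon. Among the measured compounds shown here, no pair of measured compounds isolates this exact change, so the expectation rests on the two numbers alone. Compound 2 also carries a nitro group, and a lower figure is expected for compound 4 because compound 2 gives 16.8% in this assay. The expected step is a number 9.3 percentage points lower from compound 3 to compound 4 (within the scatter), downward and probably at the edge of the scatter. Compound 4 is therefore estimated at 20%, within 6% to 34%.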

Compound 4, a percentage reported as inhibition, at one concentration (the size of the read-out at that concentration, not a potency): 44%
Compound 4: the middle estimate sits 24 percentage points below what was measured, and the stated range ends below it.
By their numbers in this assay, from the lowest: compound 2; then compound 3; then compound 4.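

In this assay, among the compounds shown here, nitro in place of trifluoromethyl on an aromatic carbon, meta to a large group, gives a number 14.7 percentage points higher from compound 3 to compound 4 (beyond the scatter) and so the nitro group at this place is compatible with the highest figure so far. The site of the nitro group also counts, since 3-nitrophenyl in place of 4-nitrophenyl on a carbonyl carbon gives a number 27.2 percentage points higher from compound 2 to compound 4 (beyond the scatter) and a nitro group therefore has no single outcome across these esters. Nothing available here accounts for either step.

Going by these compounds, whether the rise is particular to nitro stays open, as a nitrile, an amine or a carboxylic acid at the same place would be needed to test it. On these data alone, it is also open whether the 3-nitrophenyl ester keeps its standing at other concentrations or in other cell lines.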